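The compounds below may be only part of what the source reports. "The series", "measured", "known", "first", "only" and "open" are said of these compounds alone.

Compounds measured so far:
- compound 1 `C[C@@H](c1ccc(Cl)cc1)N1Cc2cncn2C(CC2(C)COC2)S1(=O)=O` — 340 nM
- compound 2 `CC(C)CC1n2cncc2CN(C2CC2)S1(=O)=O` — 930 nM
- compound 3 `C[C@@H](c1ccc(Cl)cc1)N1Cc2cncn2C(C[C@@H](O)c2ccccc2)S1(=O)=O` — 234 nM

In an assay on cells for inhibition of cytochrome P450 11B1, mitochondrial (Homo sapiens) (on this read-out higher numbers stand for weaker inhibition and lower numbers for stronger inhibition), compound 3 gives the lowest of the three numbers, although its nearest neighbour, compound 1, lies within the scatter of it; only compound 2 stands clearly apart, beyond the scatter. Compound 4 `CC(C)OCC1n2cncc2CN([C@@H](C)c2ccc(Cl)cc2)S1(=O)=O` differs from compound 3 in one place: isopropoxy in place of hydroxy(phenyl)methyl on a saturated chain carbon bound to a saturated ring carbon. Cut one bond further out, the same change reads 2-hydroxy-2-phenylethyl to isopropoxymethyl.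

For the measured compounds named here, only one measured step bears on this position, namely a 1.5-fold lower number from compound 1 to compound 3 (0.16 log units; within the scatter), which shows that swapping the 3-methyloxetan-3-yl group for hydroxy(phenyl)methyl made no difference beyond the scatter. Compound 4 carries an isopropoxy group at that carbon, which, like the group in compound 1, keeps an acceptor oxygen but loses the donor and the aromatic ring of compound 3. Going by the values given here, nothing measured here tells how that particular group behaves, so the expectation rests on the one step available: a small change, if any, in this assay. Compound 4 is therefore expected to fall near compound 1 and compound 3, with a step of a 1.5-fold higher number from compound 3 to compound 4 (0.17 log units; within the scatter) that lies within or near the scatter. The estimate for compound 4 is 350 nM, with a range from 120 nM to 1000 nM.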

Compound 4, half-maximal inhibitory concentration: 222 nM
The estimate for compound 4 lay 1.6-fold (0.20 log units) above the measured number, within the range that was stated.
By their numbers in this assay, from the lowest: compounds 4, 3 and 1 (each within the scatter of the next); then compound 2.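

In this assay the change from hydroxy(phenyl)methyl to isopropoxy gives a 1.1-fold lower number from compound 3 to compound 4 (0.02 log units; within the scatter) and so stays inside the scatter, even though the group that enters has 4 heavy atoms against 8, no ring and no hydrogen-bond donor. The earlier step between compound 1 and compound 3 had only exchanged one larger group for another, whereas this one shows that on this saturated chain carbon neither the six-membered aromatic ring nor the hydroxy donor of compound 3 is needed to keep the number where it is. With a 1.5-fold lower number from compound 1 to compound 4 (0.19 log units; within the scatter) as well, the 3-methyloxetan-3-yl, hydroxy(phenyl)methyl and isopropoxy groups all give numbers within the scatter of one another, and no other kind of measurement is at hand to explain this flat result.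

As far as these compounds go, all three of these groups carry an oxygen and no charge, so it remains open whether a plain hydrocarbon chain such as n-butyl would hold the number as well. An amine or a carboxylic acid at the same place might also move it beyond the scatter, and the compounds shown do not settle that.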